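Ring-amide nitrogen benzylation in the thiosemicarbazone series

The source may report more compounds than this note shows. Statements on the series, on what has been measured and on what is new or still open speak of the compounds shown alone.

Measured compounds, read in a functional assay on CCRF-CEM cells (Homo sapiens), with a stated time of 72 h; a lower number here means a stronger inhibitor, a higher number a weaker inhibitor:
compound 1 `O=C1Nc2ccc(Br)cc2/C1=N/NC(=S)Nc1ccc(Cl)cc1` gives 61000 nM
compound 2 `Cc1ccc(NC(=S)N/N=C2\C(=O)Nc3ccc(Br)cc32)cc1` gives 6800 nM
compound 3 `Cc1ccc(CN2C(=O)/C(=N\NC(=S)Nc3ccc(Cl)cc3)c3cc(Cl)ccc32)cc1` gives 18000 nM

Compound 2 holds the lowest number of the three. For the measured compounds named here, the only single-point step in the set is a 9.0-fold lower number from compound 1 to compound 2 (0.95 log units; beyond the scatter), which concerns the aryl substituent on the thiourea end and not the ring amide nitrogen.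

The next compound, compound 4 `Cc1ccc(NC(=S)N/N=C2\C(=O)N(Cc3ccc(F)cc3)c3ccc(Br)cc32)cc1`, differs from compound 2 by 4-fluorobenzyl in place of hydrogen on an amide-type nitrogen in a ring. Going by the values given here, no measured step bears directly on this change. Compound 3 carries a benzyl group on the same nitrogen, but it also differs from compound 2 in the halogens on both rings. Among the compounds with values here, compound 2 gives 6800 nM, and compound 3 gives 18000 nM, which shows only that a benzylated analogue with other changes sits somewhat higher, not what the benzyl itself does. In this assay the step from compound 2 to compound 4 is therefore expected to be small, with no clear direction, and a modest loss is as plausible as a gain.

Compound 4 is estimated at 8000 nM, with a range from 2500 nM to 25000 nM, meaning an expected step of a 1.2-fold higher number from compound 2 to compound 4 (0.07 log units; within the scatter).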

Compound 4, half-maximal inhibitory concentration: 132000 nM
For compound 4 the middle estimate is 17-fold (1.22 log units) below the measured one; measured number outside the range, above it.
By their numbers in this assay, from the lowest: compound 2; then compound 3; then compound 1; then compound 4.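

In this assay, for the compounds shown here, the ring amide nitrogen is not a silent position: 4-fluorobenzyl in place of hydrogen gives a 19-fold higher number from compound 2 to compound 4 (1.29 log units; beyond the scatter), a large step and the first direct reading at this site. The earlier compounds shown here could not show this, since compound 3 also carries a benzyl-type group on that nitrogen but differs from compound 2 in other places as well. The finding therefore rests on this single pair and cannot yet be extended to other substitution on the nitrogen. No available measurement bears on why the number rises.

From the compounds shown here alone, it remains open whether the step follows the loss of the amide hydrogen or the arrival of the 4-fluorobenzyl group, and a methyl or an unsubstituted benzyl on the same nitrogen of compound 2 would help separate the two. Also open, going by these compounds, is how a chain ending in an amine or a carboxylic acid at this nitrogen would read against compound 2.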